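Swapping 3-chlorophenyl for 2-hydroxyphenyl: what to expect

The compounds below may be only part of what the source reports. "The series", "measured", "known", "first", "only" and "open" are said of these compounds alone.

compound 1 `CC1(C)[C@H]2CC[C@]1(C)N(Cc1cn(-c3ccccc3Br)nn1)C(=O)C2` gives 140 nM
compound 2 `CC1(C)[C@H]2CC[C@]1(C)N(Cc1cn(-c3ccc(F)cc3)nn1)C(=O)C2` gives 200 nM
compound 3 `CC1(C)[C@H]2CC[C@]1(C)N(Cc1cn(-c3cccc(Cl)c3)nn1)C(=O)C2` gives 50 nM

In a functional assay on OVCAR-3 cells (Homo sapiens) for inhibition, read by MTT assay, with a stated time of 24 h (on this read-out lower numbers stand for stronger inhibition and higher numbers for weaker inhibition), compound 3 has the lowest number of the three (50 nM). Compound 4 `CC1(C)[C@H]2CC[C@]1(C)N(Cc1cn(-c3ccccc3O)nn1)C(=O)C2` carries 2-hydroxyphenyl in place of 3-chlorophenyl on an aromatic nitrogen. Only changes at this same place bear on it. Moving to 3-chlorophenyl gave a 2.8-fold lower number from compound 1 to compound 3 (0.45 log units; beyond the scatter) and a 4.0-fold lower number from compound 2 to compound 3 (0.60 log units; beyond the scatter) and both are modest, while the remaining swap gave a 1.4-fold higher number from compound 1 to compound 2 (0.15 log units; within the scatter) and stayed within the scatter. For the measured compounds named here, no measured compound carries 2-hydroxyphenyl, so this is an extrapolation. Leaving 3-chlorophenyl is expected to give a modest rise in the number (a 3.0-fold higher number from compound 3 to compound 4 (0.48 log units; beyond the scatter)). The estimated value for compound 4 is 150 nM (expected range 50 nM to 450 nM).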

Compound 4, half-maximal inhibitory concentration: 90 nM
The estimate for compound 4 lay 1.7-fold (0.22 log units) above the measured number; low and high end bracket the measured number.
By their numbers in this assay, from the lowest: compounds 3, 4, 1 and 2 (each within the scatter of the next, the first and the last beyond it).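

In this assay there is a 1.8-fold higher number from compound 3 to compound 4 (0.26 log units; within the scatter) and a 1.6-fold lower number from compound 1 to compound 4 (0.19 log units; within the scatter), so a phenyl ring with a hydrogen-bond donor and no halogen performs on a par with 3-chlorophenyl and 2-bromophenyl. The 2-hydroxyphenyl group also does better than 4-fluorophenyl, with a 2.2-fold lower number from compound 2 to compound 4 (0.35 log units; beyond the scatter) as the step. Nothing available explains these differences. Still open, from the compounds shown here alone, is how an amine or a carboxylic acid on the phenyl ring would fare. Going by these compounds, whether hydroxy would give a similar number elsewhere on that ring also remains open.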